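This account rests on a few compounds, and the source may have more. Where it says the series, first, only, none or still open, it means among the compounds named here.

Within the data shown here, in an ADME assay on MDCK cells (Canis lupus familiaris) for cytotoxicity (on this read-out lower numbers stand for higher toxicity in this test and higher numbers for lower toxicity in this test), compound 3 (`O=[N+]([O-])C1=NNc2nc(C(F)(F)F)nn2C1c1ccc(O)c(O)c1O`) gives 67000 nM and stands lowest of the three compounds measured so far. Compound 4 (`CSc1nc2n(n1)C(c1ccc(O)c(O)c1O)C([N+](=O)[O-])=NN2`) differs from compound 3 in one place, with methylsulfanyl in place of trifluoromethyl on an aromatic carbon. Compound 1 (`CSc1nc2n(n1)C(c1ccc(O)cc1O)C([N+](=O)[O-])=NN2`) at 201000 nM and compound 2 (`CSc1nc2n(n1)C(c1ccc(O)c(O)c1)C([N+](=O)[O-])=NN2`) at 362000 nM carry methylsulfanyl at that place too, and both read higher than compound 3. They also differ from compound 3 elsewhere, so they are only a rough guide to the size of the change. A modest upward step in this assay, just beyond the scatter, is therefore expected (a 2.2-fold higher number from compound 3 to compound 4 (0.35 log units; beyond the scatter)). For compound 4 the estimated value is 150000 nM (expected range 70000 nM to 300000 nM).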

Compound 4, half-maximal cytotoxic concentration: 196000 nM
The estimate for compound 4 lay 1.3-fold (0.12 log units) below the measured number; the measured number falls inside the stated range.
By their numbers in this assay, from the lowest: compound 3; then compounds 4, 1 and 2 (each within the scatter of the next).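

The one-place swap of trifluoromethyl for methylsulfanyl on this aromatic carbon can now be read directly in this assay (a 2.9-fold higher number from compound 3 to compound 4 (0.47 log units; beyond the scatter)), and the higher number means lower toxicity in this test. Hydroxy in place of hydrogen on an aromatic carbon gives steps that stay within the scatter (a 1.8-fold lower number from compound 2 to compound 4 (0.27 log units; within the scatter); a 1.0-fold lower number from compound 1 to compound 4 (0.01 log units; within the scatter)). Nothing measured here explains the swap. On these data alone, whether an amine or a longer chain at this place would read like methylsulfanyl or like trifluoromethyl remains open.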